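The source may report more compounds than this note shows. Statements on the series, on what has been measured and on what is new or still open speak of the compounds shown alone.

Values in an ADME assay on SH-SY5Y cells (Homo sapiens) for cytotoxicity, read by MTT assay, with a stated time of 72 h; a lower number here means a stronger inhibitor, a higher number a weaker inhibitor:
Compound 1 `COc1ccc(C(=O)N2CCN(CC(=O)N3CCN(CCCc4c[nH]c5ccc(F)cc45)CC3)CC2)cc1`: 161000 nM
Compound 2 `O=C(CN1CCN(C(=O)c2ccc(Br)cc2)CC1)N1CCN(CCCc2c[nH]c3ccc(F)cc23)CC1`: 47400 nM
Compound 3 `COc1cccc(C(=O)N2CCN(CC(=O)N3CCN(CCCc4c[nH]c5ccc(F)cc45)CC3)CC2)c1`: 79400 nM
Compound 4 `O=C(CN1CCN(C(=O)c2ccccc2Br)CC1)N1CCN(CCCc2c[nH]c3ccc(F)cc23)CC1`: not yet measured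

Two steps fix the place of compound 3 in this assay: a 2.0-fold lower number from compound 1 to compound 3 (0.31 log units; beyond the scatter), and a 1.7-fold higher number from compound 2 to compound 3 (0.22 log units; within the scatter). The change to compound 4 is 2-bromophenyl in place of 3-methoxyphenyl on a carbonyl carbon. Within the data shown here, two measured steps bear on it. Bromo in place of methoxy gave a 3.4-fold lower number from compound 1 to compound 2 (0.53 log units; beyond the scatter), and 3-methoxyphenyl in place of 4-methoxyphenyl gave a 2.0-fold lower number from compound 1 to compound 3 (0.31 log units; beyond the scatter), both modest. Among the measured compounds shown here, no measured compound carries the 2-bromophenyl group. The expected step is a 1.3-fold lower number from compound 3 to compound 4 (0.12 log units; within the scatter), slightly downward and not beyond the scatter. For compound 4 the estimated value is 60000 nM, with an expected range from 25000 nM to 130000 nM.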

Compound 4, half-maximal inhibitory concentration: 79100 nM
Beside the measured number, compound 4's estimate is 1.3-fold (0.12 log units) below it; measured number inside the range.
By their numbers in this assay, from the lowest: compounds 2, 4 and 3 (each within the scatter of the next); then compound 1.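

In this assay, 2-bromophenyl on the carbonyl carbon does not separate from 3-methoxyphenyl (a 1.0-fold lower number from compound 3 to compound 4 (0.00 log units; within the scatter)) or from 4-bromophenyl (a 1.7-fold higher number from compound 2 to compound 4 (0.22 log units; within the scatter)). Only the step from 4-methoxyphenyl lies beyond the scatter (a 2.0-fold lower number from compound 1 to compound 4 (0.31 log units; beyond the scatter)), so compound 1 alone stands apart from the other three, and a bromo group gives no readable difference between the two placements shown here. No measured evidence accounts for these values.

Still open, from the compounds shown here alone, is how 2-methoxyphenyl or unsubstituted phenyl would read on this carbonyl carbon. Going by these compounds, an amine or a carboxylic acid on the phenyl ring also remains untested.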